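Anilino substitution in the trifluoromethylbenzylthio series

A few compounds are considered here, and "the series" means these few. Any claim that something is new, unique, unknown or untested is made for them only; others in the source may bear on it.

Three analogues built on the shared core of compound 1 `FC(F)(F)c1ccc(CSc2nc(Nc3ccccc3)c3ccccc3n2)cc1` have been measured in a functional assay on MGC-803 cells (Homo sapiens) for cytotoxicity, read by MTT assay, with a stated time of 72 h; a lower number here means a stronger inhibitor, a higher number a weaker inhibitor. Compound 1 gives 22200 nM, the higher of the two numbers; its nearest neighbour is compound 3 `FC(F)(F)c1ccc(CSc2nc(Nc3cccc(Cl)c3)c3ccccc3n2)cc1`, which gives 14600 nM, and a 1.5-fold lower number from compound 1 to compound 3 (0.18 log units; within the scatter). Compound 2 `CCOc1ccccc1Nc1nc(SCc2ccc(C(F)(F)F)cc2)nc2ccccc12` is reported only as a limit, > 50000 nM, where the limit of > 50000 nM in this assay, at which 1 of the 3 values shown sits, sits. Accordingly, an at least 2.2-fold higher number from compound 1 to compound 2 (0.35 log units; beyond the scatter). Compound 4 `COc1ccc(Nc2nc(SCc3ccc(C(F)(F)F)cc3)nc3ccccc23)cc1` differs from compound 1 by methoxy in place of hydrogen on an aromatic carbon. Both measured steps alter the same anilino ring: ethoxy gave an at least modest weakening, chloro a change within the scatter. An alkoxy group is the closer precedent, so compound 4 is expected to show a step of a 1.2-fold higher number from compound 1 to compound 4 (0.07 log units; within the scatter) that stays within the scatter or leans weaker. Compound 4 is estimated at 26000 nM, range 10000 nM to 50000 nM.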

Compound 4, half-maximal inhibitory concentration: 13800 nM
For compound 4 the middle estimate is 1.9-fold (0.28 log units) above the measured one; the range from low to high includes it.
By their numbers in this assay, from the lowest: compounds 4, 3 and 1 (each within the scatter of the next). At a limit, above all of these: compound 2.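

Methoxy on an aromatic carbon para to a large group leaves the number within the scatter of the unsubstituted anilino compound, with a 1.6-fold lower number from compound 1 to compound 4 (0.21 log units; within the scatter). Compound 4 also cannot be separated from the chloro analogue, with a 1.1-fold lower number from compound 3 to compound 4 (0.02 log units; within the scatter). The weakening seen with 2-ethoxyphenyl therefore does not extend to every alkoxy-bearing anilino ring, with an at least 3.6-fold lower number from compound 2 to compound 4 (0.55 log units; beyond the scatter).

As far as these compounds go, compound 2 remains a limit, so the full size of its gap stays unknown: the limit of > 50000 nM in this assay, at which 1 of the 4 values shown sits. From the compounds shown here alone, whether an amine, a carboxylic acid or a longer alkoxy chain at this place would move the number beyond the scatter remains open.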